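Sulfonamide series: indanyl to fluorophenyl swap, lipophilicity outlook

The source may report more compounds than this note shows. Statements on the series, on what has been measured and on what is new or still open speak of the compounds shown alone.

Measured compounds:
compound 1 `CC(C)CN(C1CCc2ccc(F)cc21)S(=O)(=O)c1ccc2c(c1)C(=O)CC(C1CCOCC1)O2`: 4.03
compound 2 `CCc1ccc(N(Cc2ccccc2)S(=O)(=O)c2ccc3c(c2)C(=O)CC(C2CCOCC2)O3)cc1`: 4.84

In a physicochemical assay for lipophilicity, at pH 7.4 (a higher number here means a more lipophilic compound, a lower number a more polar compound), compound 1 gives 4.03 and stands lowest of the two numbers; compound 2 gives 4.84, a gap beyond the usual scatter. Among the compounds with values here, no step between two measured compounds that differ in a single place is available, so the following rests on the structures alone.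

Compound 3 `CC(C)CN(c1ccccc1F)S(=O)(=O)c1ccc2c(c1)C(=O)CC(C1CCOCC1)O2` is not yet measured. It differs from compound 1 in one place: 2-fluorophenyl in place of 6-fluoro-2,3-dihydro-1H-inden-1-yl on a sulfonamide nitrogen. The group that leaves carries a five-membered non-aromatic ring that the entering group lacks; the sulfonamide nitrogen and its other neighbours are unchanged.

For this assay a downward step is expected, of moderate size and beyond the scatter, the expected step being a number 0.63 log units lower from compound 1 to compound 3 (beyond the scatter). Compound 3 is therefore estimated at 3.4, within a range of 2.9 to 3.9.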

Compound 3, distribution coefficient: 3.44
Compound 3: middle estimate off by 0.04 log units, on the low side; low and high end bracket the measured number.
By their numbers in this assay, from the lowest: compound 3; then compound 1; then compound 2.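

In this assay, the sulfonamide nitrogen now has its first comparison that differs in one place: 2-fluorophenyl in place of 6-fluoro-2,3-dihydro-1H-inden-1-yl gives a number 0.59 log units lower from compound 1 to compound 3 (beyond the scatter), so this single change moves the read-out beyond the scatter. Within the data shown here, compound 2 differs from compound 1 in more than one place, so the earlier compounds could not show this. The entering group has fewer heavy atoms than the group that leaves and lacks the five-membered non-aromatic ring, but no supporting data explain the step.

On these data alone, it remains open where a phenyl without fluorine, a pyridine or a phenyl bearing a carboxylic acid would fall on this nitrogen. Also open, as far as these compounds go, is whether the step would carry over with a different saturated chain on that nitrogen.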